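From thiophen-3-yl to thiophen-2-yl in compound 2

The source may report more compounds than this note shows. Statements on the series, on what has been measured and on what is new or still open speak of the compounds shown alone.

In a functional assay on RPTEC cells (Homo sapiens) for antiproliferative activity (a lower number here means a stronger inhibitor of growth, a higher number a weaker inhibitor of growth), three related compounds have been measured. Compound 1 `c1ccc(-c2cc(-c3ccsc3)cc(-c3ccccn3)n2)nc1` gives 0.0047 ug/mL, compound 3 `c1ccc(-c2cc(-c3ccoc3)cc(-c3ccccn3)n2)nc1` gives 0.0058 ug/mL, and compound 2 `c1ccc(-c2cc(-c3ccsc3)cc(-c3cccnc3)n2)nc1` gives 0.31 ug/mL, the highest number of the three and the weakest growth inhibition among them.

The next compound, compound 4 `c1ccc(-c2cc(-c3cccs3)cc(-c3cccnc3)n2)nc1`, has the same atoms as compound 2, joined differently: thiophen-2-yl in place of thiophen-3-yl on an aromatic carbon. Thiophen-2-yl stands in place of thiophen-3-yl on an aromatic carbon, opposite the ring nitrogen.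

Among the compounds with values here, two measured steps bear on this change. The closer one is a 1.2-fold higher number from compound 1 to compound 3 (0.09 log units; within the scatter), with furan-3-yl in place of thiophen-3-yl on the same carbon, and it stays within the scatter. The other, a 66-fold higher number from compound 1 to compound 2 (1.82 log units; beyond the scatter), is large, but it comes from pyridin-3-yl in place of pyridin-2-yl, and compound 4 keeps the pyridin-3-yl group of compound 2. Within the data shown here, no measured compound carries thiophen-2-yl, so the expectation rests on one small step alone. No step beyond the scatter is expected in this assay, and no direction can be given. The estimated change is a 1.0-fold lower number from compound 2 to compound 4 (0.01 log units; within the scatter). For compound 4 the expected value is 0.3 ug/mL, with an estimated range from 0.1 ug/mL to 0.9 ug/mL.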

Compound 4, concentration for 50% growth inhibition: 0.056 ug/mL
The estimate for compound 4 lay 5.4-fold (0.73 log units) above the measured number; the whole stated range lies above it.
By their numbers in this assay, from the lowest: compounds 1 and 3 (each within the scatter of the next); then compound 4; then compound 2.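

Within the data shown here, until now the carbon opposite the ring nitrogen looked indifferent, since the only change there, furan-3-yl for thiophen-3-yl, stayed within the scatter. In this assay this position now proves sensitive: with the pyridin-3-yl group in place, merely moving the point of attachment on the thiophene, with the same atoms and the same counted features, gives a 5.5-fold lower number from compound 2 to compound 4 (0.74 log units; beyond the scatter), so how the five-membered ring is joined to the core matters even where its composition does not change. No measurement offered here explains why the two thiophene attachments differ.

The compounds shown leave open whether thiophen-2-yl would shift the number in the same direction alongside the pyridin-2-yl group of compound 1, where the thiophen-3-yl and furan-3-yl groups already give much lower numbers than compound 2 does with its pyridin-3-yl group. Among these compounds, they also leave open how this carbon would respond to a group of another kind, such as a plain phenyl ring, furan-2-yl or an amine, so the reach of this attachment effect beyond the single pair of compound 2 and compound 4 remains unknown.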